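Aryl variation on the piperazine: compound 3 to compound 4

This account rests on a few compounds, and the source may have more. Where it says the series, first, only, none or still open, it means among the compounds named here.

Measured so far:
- compound 1 `Nc1scc(CN2CCN(c3ccc(Cl)cc3Cl)CC2)c1C(=O)c1ccc(Cl)cc1`: -54%
- compound 2 `Nc1scc(CN2CCN(c3cc(Cl)cc(Cl)c3)CC2)c1C(=O)c1ccc(Cl)cc1`: -69%
- compound 3 `Nc1scc(CN2CCN(c3cccc(F)c3)CC2)c1C(=O)c1ccc(Cl)cc1`: -86%

All three share the same core and differ only in the aryl group on the amine nitrogen in the ring. In a functional assay on CHO cells with adenosine receptor A1 (Homo sapiens) as the target, read by cAMP accumulation and immunoassay, with a stated time of 6 min, tested at 1 uM (on this read-out lower numbers stand for a stronger effect and higher numbers for a weaker effect at the one concentration tested), compound 3 gives the lowest number of the three; its nearest neighbour is compound 2, and the gap to compound 1 is the widest. The steps are a number 15 percentage points lower from compound 1 to compound 2 (beyond the scatter), a number 32 percentage points lower from compound 1 to compound 3 (beyond the scatter) and a number 17 percentage points lower from compound 2 to compound 3 (beyond the scatter), each beyond the scatter.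

Compound 4 `Nc1scc(CN2CCN(c3ccc(Cl)c(Cl)c3)CC2)c1C(=O)c1ccc(Cl)cc1` carries the change (3,4-dichlorophenyl in place of 3-fluorophenyl on an amine nitrogen in a ring). Going by the values given here, no measured step covers 3,4-dichlorophenyl itself; the closest guide is the dichlorophenyl of compound 2, since a number 17 percentage points lower from compound 2 to compound 3 (beyond the scatter) shows that replacing a dichlorophenyl by 3-fluorophenyl lowered the number modestly. Reversing that direction, a modest rise in this assay is expected for compound 4 relative to compound 3, though the 2,4-dichlorophenyl of compound 1 warns that the two chlorines' pattern matters.

Compound 4 is therefore estimated at -68%, range -85% to -50%, the expected step being a number 18 percentage points higher from compound 3 to compound 4 (beyond the scatter).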

Compound 4, a percentage reported as activity, at one concentration (the size of the read-out at that concentration, not a potency): -60%
Beside the measured number, compound 4's estimate is 8 percentage points below it, and the stated range covers the measured number.
By their numbers in this assay, from the lowest: compound 3; then compounds 2, 4 and 1 (each within the scatter of the next, the first and the last beyond it).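

In this assay there is a number 26 percentage points higher from compound 3 to compound 4 (beyond the scatter), so compound 3 now stands beyond the scatter from all three dichlorophenyl compounds, and the 3,4-dichlorophenyl pattern joins the other two on the far side of that gap. Among the dichlorophenyl patterns, a number 9 percentage points higher from compound 2 to compound 4 (within the scatter) and a number 6 percentage points lower from compound 1 to compound 4 (within the scatter) leave compound 4 unresolved from either neighbour, even though compound 1 and compound 2 are separated by a number 15 percentage points lower from compound 1 to compound 2 (beyond the scatter) and so the placement of the two chlorines has no clean ordering here. Nothing available gives a reason for these differences.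

Compound 3 differs from the dichlorophenyl compounds in both the halogen and the number of substituents, so a 3-chlorophenyl group would be needed to tell these two changes apart. From the compounds shown here alone, how a methoxy group or an unsubstituted phenyl reads on the same ring nitrogen remains open.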